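Shifting the Amine on the Cyclohexyl Group

The compounds below may be only part of what the source reports. "The series", "measured", "known", "first", "only" and "open" are said of these compounds alone.

In a functional assay on K562 cells (Homo sapiens) for cytotoxicity, read by fluorescence, with a stated time of 72 h (a higher number here means a weaker inhibitor, a lower number a stronger inhibitor), compound 1 `CSc1nc(NCc2ccc(-c3ccccn3)cc2)c2[nH]nc(C(C)C)c2n1` gives 778 nM and compound 2 `CC(C)c1n[nH]c2c(NCc3ccc(-c4ccccn4)cc3)nc(N[C@@H]3CCCC[C@H]3N)nc12` gives 175 nM as the lower of the two numbers. Compound 3 `CC(C)c1n[nH]c2c(NCc3ccc(-c4ccccn4)cc3)nc(N[C@H]3CC[C@H](N)CC3)nc12` has 4-aminocyclohexyl in place of 2-aminocyclohexyl on a nitrogen on an aromatic ring and otherwise matches compound 2. Among the measured compounds shown here, the only measured step that bears on this is modest and beyond the scatter (a 4.4-fold lower number from compound 1 to compound 2 (0.65 log units; beyond the scatter)) but it swapped in a different kind of group, so it sets no direction here. In this assay the expected change is small (a 1.2-fold lower number from compound 2 to compound 3 (0.07 log units; within the scatter)) and not beyond the scatter. The estimated value for compound 3 is 150 nM with an expected range of 50 nM to 450 nM for this measurement.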

Compound 3, half-maximal inhibitory concentration: 593 nM
For compound 3 the middle estimate is 4.0-fold (0.60 log units) below the measured one, and the stated range ends below it.
By their numbers in this assay, from the lowest: compound 2; then compounds 3 and 1 (each within the scatter of the next).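

In this assay the shift from 2-aminocyclohexyl to 4-aminocyclohexyl, with the same atoms joined differently, gives a 3.4-fold higher number from compound 2 to compound 3 (0.53 log units; beyond the scatter) and so the place of the amine on the cyclohexyl ring counts. In place of methylsulfanyl, 4-aminocyclohexyl gives only a 1.3-fold lower number from compound 1 to compound 3 (0.12 log units; within the scatter) and so, among these three compounds, the edge over compound 1 belongs to compound 2 alone. Nothing available explains this difference.

Still open, on these data alone, is how 3-aminocyclohexyl would read at this nitrogen, and whether a hydroxyl in place of the amine would keep the number of compound 2.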